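Swapping a Dimethoxyphenyl Ring for a Thiophene

The source may hold more compounds than are shown below. What is called first, only, known or untested is meant among the compounds shown, and "the series" means these compounds.

Compound 1 `C=C(Br)C(=O)Nc1cccc(-c2cn3nc(-c4ccc(OC)c(OC)c4)sc3n2)c1` is the starting point of this step. In a functional assay on L1210 cells (Mus musculus) for inhibition, read by cell counting, with a stated time of 2 days (on this read-out higher numbers stand for weaker inhibition and lower numbers for stronger inhibition), compound 1 gives 42 nM, the lowest of the three numbers gathered here. The nearest of the others is compound 2 `C=C(Br)C(=O)Nc1cccc(-c2cn3c(-c4ccccc4)csc3n2)c1`, which in this assay gives 1300 nM, a gap beyond the usual scatter of repeated measurements. Furthest away is compound 3 `COc1ccc(-c2csc3nc(-c4cccc(N)c4)cn23)cc1`, which in this assay gives 19000 nM, also well beyond the scatter. Compound 1 is therefore the strongest inhibitor of the three on this read-out.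

The new compound, compound 4 `C=C(Br)C(=O)Nc1cccc(-c2cn3nc(-c4cccs4)sc3n2)c1`, keeps the core of compound 1 and differs from it in one place: thiophen-2-yl in place of 3,4-dimethoxyphenyl on an aromatic carbon. The change sits on an aromatic carbon of a five-membered aromatic ring with 2 nitrogen and 1 sulfur, part of a fused system of two rings. Among the compounds with values here, no pair of measured compounds shows this change on its own, so its size has not been seen. A modest weakening is expected, a 2.9-fold higher number from compound 1 to compound 4 (0.46 log units; beyond the scatter), though a result within the scatter would not surprise. Compound 4 is estimated at 120 nM, with a range from 30 nM to 500 nM.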

Compound 4, half-maximal inhibitory concentration: 170 nM
For compound 4 the middle estimate is 1.4-fold (0.15 log units) below the measured one; low and high end bracket the measured number.
By their numbers in this assay, from the lowest: compound 1; then compound 4; then compound 2; then compound 3.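

In this assay, thiophen-2-yl in place of 3,4-dimethoxyphenyl gives a 4.0-fold higher number from compound 1 to compound 4 (0.61 log units; beyond the scatter) on this aromatic carbon, the first view of a change made here alone. The step is modest but real, and compound 4 at 170 nM shows that a five-membered ring with no methoxy groups can sit at this position while inhibition stays in the nanomolar range. No measurement here explains the size of this step.

From the compounds shown here alone, with only these two groups compared at this position, it remains open whether the loss follows the change of ring or the loss of the two methoxy groups. Other groups, such as a pyridine ring, a simple amine or a carboxylic acid, would show how much freedom this position allows.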